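A few compounds are considered here, and "the series" means these few. Any claim that something is new, unique, unknown or untested is made for them only; others in the source may bear on it.

Measured so far:
- compound 1, `Cc1cn([C@@H]2O[C@H](CO[Si](C)(C)C(C)(C)C)[C@@]3(OS(=O)(=O)C=C3NCC(=O)O)[C@H]2O[Si](C)(C)C(C)(C)C)c(=O)n(C)c1=O`: 136000 nM
- compound 2, `Cc1cn([C@@H]2O[C@H](CO[Si](C)(C)C(C)(C)C)[C@@]3(OS(=O)(=O)C=C3NCC(=O)C(=O)N3CCC3)[C@H]2O[Si](C)(C)C(C)(C)C)c(=O)n(C)c1=O`: 84400 nM
- compound 3, `Cc1cn([C@@H]2O[C@H](CO[Si](C)(C)C(C)(C)C)[C@@]3(OS(=O)(=O)C=C3NCC(=O)OCc3ccccc3)[C@H]2O[Si](C)(C)C(C)(C)C)c(=O)n(C)c1=O`: reported only as a limit, > 200000 nM

In a functional assay on HEL cells (Homo sapiens) (a lower number here means that less compound is tolerated, a higher number that more compound is tolerated), compound 1 holds the highest of the two numbers shown. Compound 2 is its nearest neighbour, and the change of (azetidin-1-yl)carbonyl in place of hydroxy on a carbonyl carbon gives a 1.6-fold lower number from compound 1 to compound 2 (0.21 log units; within the scatter). Compound 3 sits at a limit of this assay, (the limit of > 200000 nM in this assay, at which 1 of the 3 values shown sits). Benzyl in place of hydrogen on an oxygen next to a carbonyl group gives an at least 1.4-fold higher number from compound 1 to compound 3 (0.16 log units; that floor lies within the scatter), and benzyloxy in place of (azetidin-1-yl)carbonyl on a carbonyl carbon gives an at least 2.3-fold higher number from compound 2 to compound 3 (0.37 log units; beyond the scatter).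

Compound 4, `Cc1cn([C@@H]2O[C@H](CO[Si](C)(C)C(C)(C)C)[C@@]3(OS(=O)(=O)C=C3NCCC(=O)OCc3ccccc3)[C@H]2O[Si](C)(C)C(C)(C)C)c(=O)n(C)c1=O`, differs from compound 1 by (benzyloxycarbonyl)methyl in place of carboxy on a saturated chain carbon bound to an amine nitrogen. Among the compounds with values here, the step from compound 1 to compound 3 bears on this most directly, since the benzyl ester is common to compounds 3 and 4; the extra chain carbon has no measured counterpart here. Compound 4 is therefore expected to reach the limit as well, a step of a 1.6-fold higher number from compound 1 to compound 4 (0.21 log units; within the scatter). The estimate for compound 4 is 220000 nM, with a range of 110000 nM to 450000 nM.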

Compound 4, half-maximal cytotoxic concentration: 200000 nM
The estimate for compound 4 lay 1.1-fold (0.04 log units) above the measured number; measured number inside the range.
By their numbers in this assay, from the lowest: compounds 2, 1 and 4 (each within the scatter of the next, the first and the last beyond it).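

In this assay, moving from carboxy to (benzyloxycarbonyl)methyl on a saturated chain carbon bound to an amine nitrogen gives a 1.5-fold higher number from compound 1 to compound 4 (0.17 log units; within the scatter), so this larger, ring-bearing group leaves the read-out unresolved from that of the acid. Replacing ((azetidin-1-yl)carbonyl)carbonyl at the same place with (benzyloxycarbonyl)methyl gives a 2.4-fold higher number from compound 2 to compound 4 (0.37 log units; beyond the scatter), a modest step. Compound 3 is reported only as a limit. The remaining step is a number no higher from compound 3 to compound 4 (the limit leaves the size open), and its size cannot be read: the limit of > 200000 nM in this assay, at which 1 of the 4 values shown sits.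

The effects of the added chain carbon and the benzyl ester remain tangled, and a carboxylic acid on the ethyl chain of compound 4 would separate them. A methyl ester on that chain would show whether the benzyl ring plays any part.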